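Bromo to fluoro on a shared core: little expected to change

The source may report more compounds than this note shows. Statements on the series, on what has been measured and on what is new or still open speak of the compounds shown alone.

Compound 1 `O=C1NC(=S)/C(=C/c2ccc(Br)cc2)S1` was tested in a functional assay on HEp-2 cells (Homo sapiens) for cytotoxicity, read by MTT assay, with a stated time of 72 h, tested at 2.5 ug/mL (on this read-out lower numbers stand for less inhibition of growth and higher numbers for more inhibition of growth at the one concentration tested), where compound 1 gives -0.36%. Going by the values given here, this is the highest of the two numbers measured, but its only neighbour, compound 2 `O=C1NC(=S)/C(=C/c2cccc(Br)c2)S1`, lies within the scatter: in this assay compound 2 gives -1.82%. Both values sit near zero, so neither compound noticeably slows cell growth at the dose used. Compound 3 `O=C1NC(=S)/C(=C/c2ccc(F)cc2)S1` differs from compound 1 by fluoro in place of bromo on an aromatic carbon. Among the compounds with values here, no step between measured compounds is known, yet with both numbers near zero the step of a number 0.4 percentage points higher from compound 1 to compound 3 (within the scatter) is expected to stay within the scatter. Compound 3 is therefore estimated at 0%, within -10% to 10%.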

Compound 3, percent growth inhibition at one concentration: -4.51%
Compound 3: the middle estimate sits 4.5 percentage points above what was measured, within the range that was stated.
By their numbers in this assay, from the lowest: compounds 3, 2 and 1 (each within the scatter of the next).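

In this assay, fluoro in place of bromo on the aromatic carbon gives a number 4.2 percentage points lower from compound 1 to compound 3 (within the scatter), so at this position the change from one halogen to another does not move the read-out beyond the usual scatter. Compound 1 and compound 3 both remain near zero, showing no clear growth inhibition at the one concentration tested. Nothing available here bears further on this result. Still open, as far as these compounds go, is whether a very different group at this position, such as an amine or a carboxylic acid, would produce measurable growth inhibition.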